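A few compounds are considered here, and "the series" means these few. Any claim that something is new, unique, unknown or untested is made for them only; others in the source may bear on it.

Compounds measured so far in a functional assay on the whole organism (strain albino) for inhibition, with Rattus norvegicus as the target, read by paw edema, with a stated time of 1 h, at a dose of 0.28 mmol/kg by the oral route; on this read-out lower numbers stand for less inhibition and higher numbers for more inhibition at the one dose given (going by the name of the read-out):

compound 1, `CCn1c(SC/C(=N/O)c2ccccc2)nnc1-c1ccc(OC)c(OC)c1`: 61%
compound 2, `C=CCn1c(SC/C(=N/O)c2ccccc2)nnc1-c1cc(OC)c(OC)c(OC)c1`: 61%
compound 3, `CCn1c(SCC(=O)c2ccccc2)nnc1-c1ccc(OC)c(OC)c1`: 42%

Compound 1 and compound 2 sit level at the digits printed, within the scatter of each other; how their two cores differ is not broken down here. Compound 3 carries the change a group of 8 heavy atoms (7 carbon, 1 oxygen; one six-membered aromatic ring of carbon only) in place of a group of 9 heavy atoms (7 carbon, 1 nitrogen, 1 oxygen; one six-membered aromatic ring of carbon only), on a saturated chain carbon bound to a sulfur relative to compound 1, and that step gave a number 19 percentage points lower from compound 1 to compound 3 (beyond the scatter) in this assay.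

Compound 4, `C=CCn1c(SCC(=O)c2ccccc2)nnc1-c1cc(OC)c(OC)c(OC)c1`, is not yet measured. It differs from compound 2 by a group of 8 heavy atoms (7 carbon, 1 oxygen; one six-membered aromatic ring of carbon only) in place of a group of 9 heavy atoms (7 carbon, 1 nitrogen, 1 oxygen; one six-membered aromatic ring of carbon only), on a saturated chain carbon bound to a sulfur, the same change, in the same place, that took compound 1 to compound 3. Since the two measured starting points read alike, the step is expected to be of about the same size as a number 19 percentage points lower from compound 1 to compound 3 (beyond the scatter), that is a number 19 percentage points lower from compound 2 to compound 4 (beyond the scatter). Within the data shown here, compound 4 is therefore expected to give 42% in this assay, with a likely range from 30% to 55%; only one prior instance of the step is known, so the range is kept wide.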

Compound 4, a percentage reported as inhibition, in the whole organism at one dose (the size of the read-out at that dose, not a potency): 49%
The estimate for compound 4 lay 7 percentage points below the measured number, within the range that was stated.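

In this assay, putting benzoyl on the saturated chain carbon bound to a sulfur gave a number 12 percentage points lower from compound 2 to compound 4 (beyond the scatter) and so lowered the number on this core as well. The two instances of the change agree in direction, and their sizes cannot be told apart: the same change on two cores in this assay, a number 19 percentage points lower (beyond the scatter) from compound 1 to compound 3 and a number 12 percentage points lower (beyond the scatter) from compound 2 to compound 4, 7 percentage points apart, within the scatter of two such steps. This supports carrying the change between these two cores, but two pairs tested at a single dose do not show that it would carry to other cores in the series.

The compounds shown leave open how an amine or a carboxylic acid would read on that same chain carbon. They also do not separate the contributions of the parts in which the two cores differ.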